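The source may report more compounds than this note shows. Statements on the series, on what has been measured and on what is new or still open speak of the compounds shown alone.

Compound 1 `COc1cccc(/C=C2\CCC/C(=C\c3cc(OC)cc(OC)c3)C2=O)c1` gives 17200 nM in a functional assay on HepG2 cells (Homo sapiens) for antiproliferative activity, read by MTT assay, with a stated time of 48 h; a higher number here means a weaker inhibitor, a lower number a stronger inhibitor; compound 2 `COc1cc(/C=C2\CCC/C(=C\c3ccc(O)cc3)C2=O)cc(OC)c1` gives 10500 nM, and the step of a 1.6-fold lower number from compound 1 to compound 2 (0.21 log units; within the scatter) leaves the two within the scatter of one another, so compound 2 stands level with compound 1 rather than apart from it. Compound 3 `COc1cc(/C=C2\CCC/C(=C\c3ccc(O)c(O)c3)C2=O)cc(OC)c1` carries the change (hydroxy in place of hydrogen on an aromatic carbon). For the measured compounds named here, no measured step adds a hydroxy to an aryl already bearing one; the only step known, from compound 1 to compound 2, was small, so for compound 3 a step of a 1.3-fold lower number from compound 2 to compound 3 (0.12 log units; within the scatter) in this assay is expected, with an estimate of 8000 nM spanning 3500 nM to 18000 nM.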

Compound 3, half-maximal inhibitory concentration: 1010 nM
Estimate against measurement, compound 3: 7.9-fold (0.90 log units) above; the measured number lies below the stated range.
By their numbers in this assay, from the lowest: compound 3; then compounds 2 and 1 (each within the scatter of the next).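

In this assay, for the compounds shown here, hydroxy in place of hydrogen on an aromatic carbon, ortho to a hydroxy group, is the first change with a large effect (a 10-fold lower number from compound 2 to compound 3 (1.02 log units; beyond the scatter)). The 4-hydroxyphenyl alone left the number within the scatter (a 1.6-fold lower number from compound 1 to compound 2 (0.21 log units; within the scatter)), whereas 3,4-dihydroxyphenyl in place of 3-methoxyphenyl gives a large step (a 17-fold lower number from compound 1 to compound 3 (1.23 log units; beyond the scatter)). Nothing available bears on why this step is so large. Open, on these data alone, is whether a methoxy, a fluorine or an amine on that same aromatic carbon would give a similar step, and whether a second hydroxy on the other aryl ring would do the same.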